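A few compounds are considered here, and "the series" means these few. Any claim that something is new, unique, unknown or untested is made for them only; others in the source may bear on it.

Compound 1 `CCc1ccc2nc(C(=O)Nc3c(F)cc(-c4cccc(F)c4)cc3F)c(C)c(O)c2c1` gives 31.2% in a functional assay on Hep 3B2 cells (Homo sapiens) for antiproliferative activity, read by MTT assay, with a stated time of 24 h, tested at 3.7 ug/mL; on this read-out lower numbers stand for a weaker effect and higher numbers for a stronger effect at the one concentration tested; of the two compounds measured it is the one with the larger figure, though the gap to compound 2 lies within the scatter. Compound 2 `Cc1c(C(=O)Nc2c(F)cc(-c3cccc(F)c3)cc2F)nc2ccc(F)cc2c1O` gives 22.3% in this assay, a step of a number 8.9 percentage points lower from compound 1 to compound 2 (within the scatter) for fluoro in place of ethyl on an aromatic carbon. Compound 3 `Cc1c(C(=O)Nc2c(F)cc(-c3cccc(F)c3)cc2F)nc2ccc(C(F)(F)F)cc2c1O` carries the change trifluoromethyl in place of ethyl on an aromatic carbon at the same carbon. Within the data shown here, the single step bearing on it stayed within the scatter, so no step beyond the scatter is expected in this assay from compound 1 to compound 3, at most a slight drop of a number 5.2 percentage points lower from compound 1 to compound 3 (within the scatter). Compound 3 is estimated at 26%, between 12% and 40%.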

Compound 3, a percentage reported as inhibition, at one concentration (the size of the read-out at that concentration, not a potency): 31.2%
Compound 3: middle estimate off by 5.2 percentage points, on the low side, within the range that was stated.
By their numbers in this assay, from the lowest: compounds 2, 1 and 3 (each within the scatter of the next).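

In this assay, trifluoromethyl in place of ethyl on this aromatic carbon gives no change at the digits printed from compound 1 to compound 3 (within the scatter) and so does not separate the two groups. Trifluoromethyl in place of fluoro gives a number 8.9 percentage points higher from compound 2 to compound 3 (within the scatter) and adds no step beyond the scatter, so this carbon has so far shown no clear response to any of the three groups. Nothing on hand explains this result.

On these data alone, whether an amine, a carboxylic acid or a longer chain on this carbon would move the figure beyond the scatter remains open.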